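A few compounds are considered here, and "the series" means these few. Any claim that something is new, unique, unknown or untested is made for them only; others in the source may bear on it.

Compound 1 `O=C(O[C@H]1C[C@H](n2cc(F)c(=O)[nH]c2=O)O[C@@H]1COP(=O)(O)Oc1ccc2ncccc2c1)c1ccccc1`: 7.7 h
Compound 2 `CCCCCCCCCC[n+]1cccc(OP(=O)([O-])OC[C@H]2O[C@@H](n3cc(F)c(=O)[nH]c3=O)C[C@@H]2OC(=O)c2ccccc2)c1`: 16.5 h

Both values come from a physicochemical assay for metabolic stability, read by HPLC, tested at 2 mM; a higher number here means that the compound lasts longer, a lower number that the compound disappears faster. Compound 2 stands highest of the two, and its gap to compound 1 lies beyond the scatter. Compound 3 `CCOC(=O)C[n+]1cccc(OP(=O)([O-])OC[C@H]2O[C@@H](n3cc(F)c(=O)[nH]c3=O)C[C@@H]2OC(=O)c2ccccc2)c1` has not yet been measured. It differs from compound 2 by ethoxycarbonyl in place of nonyl on a saturated chain carbon bound to an aromatic nitrogen, with ethoxycarbonyl in place of nonyl on a saturated chain carbon bound to an aromatic nitrogen. Among the measured compounds shown here, no measured pair shows this change alone, so its size remains a judgement. A downward step beyond the scatter is expected in this assay, estimated as a 3.3-fold lower number from compound 2 to compound 3 (0.52 log units; beyond the scatter). For compound 3 the estimated half-life is 5 h, with an expected range of 1.5 h to 14 h.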

Compound 3, half-life: 1.1 h
Compound 3: middle estimate off by 4.5-fold (0.66 log units), on the high side; measured number below the stated range.
By their numbers in this assay, from the lowest: compound 3; then compound 1; then compound 2.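

In this assay, ethoxycarbonyl in place of nonyl on a saturated chain carbon bound to an aromatic nitrogen gives a 15-fold lower number from compound 2 to compound 3 (1.18 log units; beyond the scatter) and so marks a large step beyond the scatter. Among the compounds shown here, this is the first pair to differ in this one place, and it shows that the half-life depends strongly on what this position carries. Nothing shown gives a reason for the step. Still open, on these data alone, is whether the ester or the shorter chain sets the result. A butyl chain or a carboxylic acid in this place would help separate the two.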